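The source may hold more compounds than are shown below. What is called first, only, known or untested is meant among the compounds shown, and "the series" means these compounds.

Compound 1 `NC(=O)c1c(NC(=O)c2ccccc2C(F)(F)F)sc2c1CCN(C(=S)Nc1ccccc1Cl)C2` is the reference point. In a functional assay on MKN-74 cells (Homo sapiens) for antiproliferative activity, with a stated time of 24 h (a lower number here means a stronger inhibitor, a higher number a weaker inhibitor), compound 1 gives 21900 nM. Compound 2 `COc1ccccc1C(=O)Nc1sc2c(c1C(N)=O)CCN(C(=S)Nc1ccccc1Cl)C2`, with methoxy in place of trifluoromethyl on an aromatic carbon, gives 20500 nM, and the step of a 1.1-fold lower number from compound 1 to compound 2 (0.03 log units; within the scatter) stays within the scatter. Compound 3 `CSc1ccccc1C(=O)Nc1sc2c(c1C(N)=O)CCN(C(=S)Nc1ccccc1Cl)C2`, with methylsulfanyl in place of trifluoromethyl on an aromatic carbon, gives 6550 nM; the step of a 3.3-fold lower number from compound 1 to compound 3 (0.52 log units; beyond the scatter) goes beyond the scatter, as does a 3.1-fold lower number from compound 2 to compound 3 (0.50 log units; beyond the scatter). All three measured steps exchange a group on an aromatic carbon elsewhere in the molecule; none of them touches the chloro.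

Compound 4 `NC(=O)c1c(NC(=O)c2ccccc2C(F)(F)F)sc2c1CCN(C(=S)Nc1ccccc1F)C2` differs from compound 1 by fluoro in place of chloro on an aromatic carbon. Within the data shown here, no measured step bears directly on this exchange, so there is no ground for expecting a step beyond the scatter in this assay in either direction. Compound 4 is therefore expected to give about 21900 nM, with a range from 9000 nM to 50000 nM. The expected step of no change at the digits printed from compound 1 to compound 4 (within the scatter) is estimated to lie within the scatter.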

Compound 4, half-maximal inhibitory concentration: 19600 nM
Compound 4: middle estimate off by 1.1-fold (0.05 log units), on the high side; low and high end bracket the measured number.
By their numbers in this assay, from the lowest: compound 3; then compounds 4, 2 and 1 (each within the scatter of the next).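

In this assay, the first exchange at this position among the compounds shown, fluoro in place of chloro on the 2-chlorophenyl group, is a 1.1-fold lower number from compound 1 to compound 4 (0.05 log units; within the scatter). With trifluoromethyl on the other side of the molecule, this position therefore carries either halogen without a step beyond the scatter, whereas the exchange elsewhere in the molecule remains the one that goes beyond it, at a 3.3-fold lower number from compound 1 to compound 3 (0.52 log units; beyond the scatter). No measured evidence on the compounds accounts for this result.

Fluoro stands at this position only in compound 4, so it remains open whether the two halogens would also match alongside methoxy or methylsulfanyl. As far as these compounds go, how the position would respond to bromo, to an amine or to a carboxylic acid also remains open.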